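Methyl on the benzylamino chain of compound 3

The source may hold more compounds than are shown below. What is called first, only, known or untested is meant among the compounds shown, and "the series" means these compounds.

In a functional assay on SK-BR-3 cells (Homo sapiens) for antiproliferative activity (a lower number here means a stronger inhibitor, a higher number a weaker inhibitor), compound 3 `CC(C)=CCc1cc(C(=O)Nc2cc3ccc(OCCCNCc4ccccc4)c(C)c3oc2=O)ccc1O` gives 470 nM as the lowest number of the three measured, against compound 1 `CCN(CC)CCCOc1ccc2cc(NC(=O)c3ccc(O)c(CC=C(C)C)c3)c(=O)oc2c1C` at 4900 nM and compound 2 `CC(C)=CCc1cc(C(=O)Nc2cc3ccc(OCCCNCC(N)=O)c(C)c3oc2=O)ccc1O` at 2290 nM on the same read-out. The change to compound 4 `CC(C)=CCc1cc(C(=O)Nc2cc3ccc(OCCCN[C@H](C)c4ccccc4)c(C)c3oc2=O)ccc1O` is methyl in place of hydrogen on a saturated chain carbon bound to an amine nitrogen and an aromatic carbon in the form of methyl in place of hydrogen on a saturated chain carbon bound to an amine nitrogen and an aromatic carbon, turning benzylamino into (1-phenylethyl)amino. Changes at the amine gave a 10-fold lower number from compound 1 to compound 3 (1.02 log units; beyond the scatter) and a 4.9-fold lower number from compound 2 to compound 3 (0.69 log units; beyond the scatter) as well as a 2.1-fold lower number from compound 1 to compound 2 (0.33 log units; beyond the scatter) but none of these places a methyl on this carbon, so they show that the amine substituent matters without giving a direction here. Going by these compounds, no step beyond the scatter is expected in this assay with a 1.1-fold higher number from compound 3 to compound 4 (0.03 log units; within the scatter) as the estimate, although a larger move either way remains open. Compound 4 is estimated at 500 nM with 200 nM to 1250 nM as the expected range.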

Compound 4, half-maximal inhibitory concentration: 1000 nM
Compound 4: middle estimate off by 2.0-fold (0.30 log units), on the low side; the range from low to high includes it.
By their numbers in this assay, from the lowest: compound 3; then compound 4; then compound 2; then compound 1.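

In this assay, this saturated chain carbon bound to an amine nitrogen and an aromatic carbon does not tolerate methyl in place of hydrogen without loss, giving a 2.1-fold higher number from compound 3 to compound 4 (0.33 log units; beyond the scatter). Even so, (1-phenylethyl)amino retains an advantage over the other two amine substituents, with a 2.3-fold lower number from compound 2 to compound 4 (0.36 log units; beyond the scatter) and a 4.9-fold lower number from compound 1 to compound 4 (0.69 log units; beyond the scatter). No measurement available here explains the loss at this carbon.

Going by these compounds, whether the loss follows from the methyl itself or from its configuration stays open. The opposite enantiomer of compound 4, or an ethyl or hydroxymethyl group on this carbon, would help separate these possibilities.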